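Arylating the thiourea nitrogen of a quinoline thiosemicarbazone

This account rests on a few compounds, and the source may have more. Where it says the series, first, only, none or still open, it means among the compounds named here.

Compound 1 `S=C(NCc1ccccc1)N/N=C/c1ccc2ccccc2n1`: in a functional assay on HT-29 cells (Homo sapiens) for antiproliferative activity, read by sulforhodamine B assay, with a stated time of 72 h (on this read-out lower numbers stand for stronger inhibition and higher numbers for weaker inhibition), compound 1 gives 75700 nM.
Compound 2 `NC(=S)N/N=C/c1nc2ccccc2s1`: in this assay compound 2 gives only a limit, > 100000 nM.
Compound 3 `CN(C)C(=S)N/N=C/c1cnc2ccccc2n1`: in this assay compound 3 gives 450 nM.

Among the two numbers actually recorded in this assay, compound 1 holds the higher one. The gap between compound 1 and compound 3 is well beyond the usual scatter. Compound 2 sits at the assay limit of > 100000 nM in this assay, at which 1 of the 3 values shown sits, and so gives no number to rank. None of these three differs from another in one place only, so no single measured step can be read off.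

Compound 4 `S=C(N/N=C/c1ccc2ccccc2n1)Nc1cccc(Cl)c1` is the next compound to be measured. It differs from compound 1 by 3-chlorophenyl in place of benzyl on an amide-type nitrogen. The shared core of compound 1 is kept, and the thiocarbonyl and its hydrazone are unchanged.

Among the compounds with values here, no measured pair in this set speaks to an aryl for benzyl swap at this nitrogen, so the size of the step in this assay cannot be drawn from the data; it is expected to be modest and toward a lower number. Compound 4 is estimated at 20000 nM, with a range from 3000 nM to 100000 nM, which is an expected step of a 3.8-fold lower number from compound 1 to compound 4 (0.58 log units; beyond the scatter).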

Compound 4, half-maximal inhibitory concentration: 48100 nM
Compound 4: the middle estimate sits 2.4-fold (0.38 log units) below what was measured, and the stated range covers the measured number.
By their numbers in this assay, from the lowest: compound 3; then compounds 4 and 1 (each within the scatter of the next). At a limit, above all of these: compound 2.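

In this assay, within the data shown here, the change gives the first single measured step of this set (a 1.6-fold lower number from compound 1 to compound 4 (0.20 log units; within the scatter)). Among these compounds, on this read-out, then, 3-chlorophenyl and benzyl cannot be told apart on the amide-type nitrogen, which the earlier compounds could not show because none of them differed from another in one place only. Nothing among the measurements shown accounts for this outcome.

Going by these compounds, what stays open is whether the chlorine and the direct attachment of the ring to the nitrogen each matter on their own, since a plain phenyl or a 2-phenylethyl chain at this nitrogen would be needed to separate the two, and the step seen here says nothing about either of them. It is also open whether this nitrogen responds at all to a group of a different kind, such as a morpholine ring or a short carboxylic acid chain, on the shared core of compound 1, as the single step shown covers only one exchange of one ring-bearing group for another.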